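The source may hold more compounds than are shown below. What is called first, only, known or untested is meant among the compounds shown, and "the series" means these compounds.

Measured in a functional assay on MCF7 cells (Homo sapiens) for antiproliferative activity (on this read-out higher numbers stand for weaker inhibition and lower numbers for stronger inhibition), all three values being limits:
compound 1 `CC(=O)Nc1ccc(-c2nc3ccccc3s2)cc1Cl` gives > 10 nM
compound 2 `CC(=O)Nc1ccc(-c2nc3ccccc3s2)cc1Br` gives > 10 nM
compound 3 `CC(=O)Nc1ccc(-c2nc3ccccc3s2)cc1I` gives > 100 nM

Compound 3 thus has no number, only the limit > 100 nM and (the limit of > 100 nM in this assay, at which 1 of the 3 values shown sits). The other two halogen compounds share (the limit of > 10 nM in this assay, at which 2 of the 3 values shown sit). The next change is nitro in place of iodo on an aromatic carbon, ortho to an acetamido group, and gives compound 4 `CC(=O)Nc1ccc(-c2nc3ccccc3s2)cc1[N+](=O)[O-]` with nitro in place of iodo on an aromatic carbon. For the measured compounds named here, three measured steps bear on it, and none has a readable size: a step that the two limits leave unreadable from compound 1 to compound 2; a step that the two limits leave unreadable from compound 1 to compound 3; a step that the two limits leave unreadable from compound 2 to compound 3. They offer no size or direction to carry over. The expected move is a step that the limit leaves unreadable from compound 3 to compound 4 in this assay, with no firm direction expected. Compound 4 is estimated at 150 nM, with an expected range of 20 nM to 1000 nM, and may again be reported only as a limit.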

Compound 4, half-maximal inhibitory concentration: > 1000 nM
Compound 4: no number, only a limit; the forecaster's own chance of this, stated with the estimate: 70%; at least 6.6-fold (0.82 log units) between middle value and limit.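

Compound 4 gives > 1000 nM, which is a limit, so its steps from compound 1, compound 2 and compound 3 cannot be read. The compounds shown leave open any order among chloro, bromo, iodo and nitro, since all four values are limits.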